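Replacing the methylpyrazole of compound 3 with an open chain

A few compounds are considered here, and "the series" means these few. Any claim that something is new, unique, unknown or untested is made for them only; others in the source may bear on it.

Measured in a functional assay on EBC-1 cells (Homo sapiens) for antiproliferative activity, with a stated time of 72 h; on this read-out lower numbers stand for stronger inhibition and higher numbers for weaker inhibition:
Compound 1 `Cn1cc(-c2cn3c(Cc4ccc5ncccc5c4)cnc3cc2Cl)cn1`: "not determined" (no result reported)
Compound 2 `Cn1cc(-c2cc(C#N)c3ncc(Cc4ccc5ncccc5c4)n3c2)cn1`: "not determined" (no result reported)
Compound 3 `Cn1cc(-c2cc(F)c3ncc(Cc4ccc5ncccc5c4)n3c2)cn1`: 0.27 nM

Compound 3 is the only one of the three with a number, so it can be ranked against nothing: compound 1 and compound 2 have no result in this assay. The next compound to be tested is compound 4 `CCO/N=C(\C)c1cc(F)c2ncc(Cc3ccc4ncccc4c3)n2c1`. In it the 1-methyl-1H-pyrazol-4-yl group gives way to a group with no ring, on an aromatic carbon of a six-membered aromatic ring with 1 nitrogen, meta to a fluoro group (a group of 6 heavy atoms (4 carbon, 1 nitrogen, 1 oxygen; no ring) in place of a group of 6 heavy atoms (4 carbon, 2 nitrogen; one five-membered aromatic ring with 2 hetero atoms), on an aromatic carbon). Within the data shown here, no measured pair shows what such a change does, so the expectation rests on compound 3 alone, with its very low 0.27 nM as the starting point. A step of a 5.6-fold higher number from compound 3 to compound 4 (0.74 log units; beyond the scatter) is expected, towards weaker inhibition and beyond the usual scatter, although the uncertainty is wide. The estimate for compound 4 is 1.5 nM as the expected value, in a range from 0.2 nM to 12 nM in this estimate.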

Compound 4, half-maximal inhibitory concentration: 1480 nM
Beside the measured number, compound 4's estimate is 990-fold (2.99 log units) below it; the measured number lies above the stated range.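

In this assay, the change gives a 5500-fold higher number from compound 3 to compound 4 (3.74 log units; beyond the scatter), so at this place on the aromatic carbon the 1-methyl-1H-pyrazol-4-yl group cannot be exchanged freely, even for a group with the same count of heavy atoms, hydrogen-bond donors and hydrogen-bond acceptors. Those matching counts therefore do not preserve the activity of compound 3, while the two groups differ in that one holds a five-membered aromatic ring and the other has no ring. No measurement shown here accounts for the loss.

The compounds shown leave open whether the loss follows from removing the ring or from this particular chain. As far as these compounds go, how an amine, a carboxylic acid, a longer chain or a thiazole ring would fare at this place also remains open.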